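The compounds below may be only part of what the source reports. "The series", "measured", "known", "first", "only" and "open" are said of these compounds alone.

In a functional assay on the whole organism for inhibition, with Cavia porcellus as the target (a lower number here means that less compound is needed, a higher number that more compound is needed for the effect), compound 1 (`C=CCCn1c(=O)c2[nH]cnc2n(CCC)c1=O`) gives 1.84 mg/kg and compound 2 (`CCCn1c(=O)n(C)c(=O)c2[nH]cnc21`) gives 4.44 mg/kg while compound 3 (`CCCn1cnc2c1c(=O)n(C)c(=O)n2CCC`) gives 27.5 mg/kg as the highest of the three numbers. Compound 4 (`CCCn1c(=O)n(C)c(=O)c2c1ncn2CCOCC`) has ethoxy in place of methyl on a saturated chain carbon, two bonds along the chain from an aromatic nitrogen. For the measured compounds named here, two measured steps bear on this change. Propyl in place of hydrogen on an aromatic nitrogen gave a 6.2-fold higher number from compound 2 to compound 3 (0.79 log units; beyond the scatter) and hydrogen in place of allyl gave a 2.4-fold higher number from compound 1 to compound 2 (0.38 log units; beyond the scatter) as modest moves. Going by the values given here, no measured compound carries ethoxy, so the direction is uncertain. The expected change is a modest one toward a lower number, estimated as a 1.5-fold lower number from compound 3 to compound 4 (0.18 log units; within the scatter) in this assay overall. For compound 4 the estimated value is 18 mg/kg with an expected range from 5 mg/kg to 60 mg/kg as its limits.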

Compound 4, dose for half-maximal effect: 12.1 mg/kg
Beside the measured number, compound 4's estimate is 1.5-fold (0.17 log units) above it; measured number inside the range.
By their numbers in this assay, from the lowest: compound 1; then compound 2; then compound 4; then compound 3.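

In this assay, ethoxy in place of methyl on a saturated chain carbon, two bonds along the chain from an aromatic nitrogen, gave a 2.3-fold lower number from compound 3 to compound 4 (0.36 log units; beyond the scatter), the first sign that this chain can be extended with an ether oxygen and lower the number. Against the unsubstituted nitrogen, 2-ethoxyethyl in place of hydrogen still gave a 2.7-fold higher number from compound 2 to compound 4 (0.44 log units; beyond the scatter), so this chain recovers only part of the rise seen with propyl. Nothing available explains either step. As far as these compounds go, whether an amine or a longer ether chain at this place would lower the number further remains open.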